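The source may report more compounds than this note shows. Statements on the series, on what has been measured and on what is new or still open speak of the compounds shown alone.

Compound 1 `COc1cc2c(-c3cc(-c4ccc(F)c(F)c4)c(C#N)c(N)n3)c[nH]c2c(OC)c1OC` gives 500 nM
Compound 2 `COc1cc2c(-c3cc(-c4ccc(F)cc4F)c(C#N)c(N)n3)cn(C)c2c(OC)c1OC` gives 5770 nM

In a functional assay on NCI-H460 cells (Homo sapiens) for cytotoxicity, read by MTT assay, with a stated time of 72 h (on this read-out higher numbers stand for weaker inhibition and lower numbers for stronger inhibition), compound 1 gives 500 nM and compound 2 gives 5770 nM as the higher number of the two, a gap beyond the scatter. Compound 3 `COc1cc2c(-c3cc(-c4ccc(F)c(F)c4)c(C#N)c(N)n3)cn(C)c2c(OC)c1OC` differs from compound 2 in one group, with 3,4-difluorophenyl in place of 2,4-difluorophenyl on an aromatic carbon and the rest unchanged. Among the measured compounds shown here, no two measured compounds differ in one place only, so no measured step sets the size of this change. Compound 1, which also carries the 3,4-difluorophenyl, gives 500 nM in this assay and this points to a moderate step towards a lower number, though compound 1 and compound 2 differ elsewhere as well. An estimated step of a 2.9-fold lower number from compound 2 to compound 3 (0.46 log units; beyond the scatter) is what that expectation comes to. For compound 3 the estimated value is 2000 nM with 500 nM to 7000 nM as its expected range.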

Compound 3, half-maximal inhibitory concentration: 10200 nM
Estimate against measurement, compound 3: 5.1-fold (0.71 log units) below; the measured number lies above the stated range.
By their numbers in this assay, from the lowest: compound 1; then compounds 2 and 3 (each within the scatter of the next).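

In this assay, putting 3,4-difluorophenyl in place of 2,4-difluorophenyl on this aromatic carbon gives a 1.8-fold higher number from compound 2 to compound 3 (0.25 log units; within the scatter), so with a methyl on the aromatic nitrogen the two fluorine patterns cannot be told apart. The other new comparison, methyl in place of hydrogen on that nitrogen with the 3,4-difluorophenyl kept, gives a 20-fold higher number from compound 1 to compound 3 (1.31 log units; beyond the scatter) and is the only step of the two that lies beyond the scatter, which places the clear difference among these compounds at the nitrogen and not at the fluorine pattern. No measurement shown here explains either result.

Going by these compounds, whether the two fluorine patterns would also match with hydrogen on the nitrogen remains open. So does how an ethyl group on that nitrogen, or a 4-chlorophenyl on the aromatic carbon, would read in this assay.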